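The source may hold more compounds than are shown below. What is called first, only, known or untested is meant among the compounds shown, and "the series" means these compounds.

In an ADME assay on microsomes from liver (Homo sapiens) for metabolic stability, with a stated time of 10 min, tested at 0.5 uM (on this read-out higher numbers stand for a more stable compound and lower numbers for a less stable compound), three compounds sharing one core have been measured: compound 1 `COc1ncc(NC(=O)[C@H](C)[C@H]2CC[C@@H](c3ccnc4ccc(F)cc43)CC2)cn1` gives 73% and compound 2 `C[C@@H](c1nc2ccc(Cl)cc2[nH]1)[C@H]1CC[C@@H](c2ccnc3ccc(F)cc32)CC1` gives 48% while compound 3 `C[C@@H](NS(=O)(=O)c1ccc(Cl)cc1)[C@H]1CC[C@@H](c2ccnc3ccc(F)cc32)CC1` gives 29% as the lowest of the three, beyond the scatter from both others. Compound 4 `C[C@@H](NC(=O)c1ccccc1Cl)[C@H]1CC[C@@H](c2ccnc3ccc(F)cc32)CC1` carries (2-chlorophenyl)carbonyl in place of (4-chlorophenyl)sulfonyl on an amine nitrogen and awaits measurement. Going by the values given here, no measured pair isolates this change, so the expectation rests loosely on the carbonyl-bearing compound 1 at 73% against the sulfonyl-bearing compound 3 at 29% only. A moderate rise in this assay is expected, estimated as a number 16 percentage points higher from compound 3 to compound 4 (beyond the scatter) in size. Compound 4 is estimated at 45% with an expected range from 27% to 65% overall.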

Compound 4, percent of the compound remaining: 21%
Compound 4: the middle estimate sits 24 percentage points above what was measured; the whole stated range lies above it.
By their numbers in this assay, from the lowest: compounds 4 and 3 (each within the scatter of the next); then compound 2; then compound 1.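

In this assay, (2-chlorophenyl)carbonyl in place of (4-chlorophenyl)sulfonyl on an amine nitrogen gives a number 8 percentage points lower from compound 3 to compound 4 (within the scatter) and so does not separate the two groups at this place. Going by these compounds alone, this is the first pair that isolates a change here, and it shows that swapping the sulfonyl group for a carbonyl group, with the chlorine moved as the names state, leaves the read-out within the scatter. Nothing available explains this result.

On these data alone, because the linking group and the chlorine's position change together, their separate contributions remain open. So does the outcome with an acetyl group or a pyridine ring on this nitrogen.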